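The compounds below may be only part of what the source reports. "The series", "measured", "known", "first", "only" and "open" are said of these compounds alone.

Compound 1 `CC(C)C[C@H](N)CN(C(=O)[C@@H]1C[C@H]1c1ccccc1)c1ccc(-c2cccs2)cc1`: 1500 nM
Compound 2 `COc1ccccc1-c1ccc(N(C[C@@H](N)CC(C)C)C(=O)[C@@H]2C[C@H]2c2ccccc2)cc1`: 3200 nM

Within the data shown here, in a functional assay for agonist activity at G protein-coupled receptor 88 (Homo sapiens), read by HTRF and cAMP accumulation (on this read-out higher numbers stand for an effect only at larger amounts of compound and lower numbers for an effect already at smaller amounts), compound 2 gives 3200 nM, the highest of the two numbers measured so far; its nearest neighbour is compound 1, which gives 1500 nM. Among the measured compounds shown here, the one measured step, a 2.1-fold higher number from compound 1 to compound 2 (0.33 log units; beyond the scatter), came from the exchange of thiophen-2-yl for 2-methoxyphenyl on an aromatic carbon and raised the number modestly. Compound 3 `CC(C)C[C@H](N)CN(C(=O)[C@@H]1C[C@H]1c1ccccc1)c1ccc(-c2ccc(F)cc2)cc1` has not yet been measured. It differs from compound 2 in one place: 4-fluorophenyl in place of 2-methoxyphenyl on an aromatic carbon. For the measured compounds named here, no measured step swaps one six-membered aromatic ring of carbon only for another at this position, so the step from compound 1 to compound 2 bears on it only loosely, showing that a change of the group on this aromatic carbon moves the number modestly rather than greatly. In this assay a step of about a 1.6-fold lower number from compound 2 to compound 3 (0.20 log units; within the scatter) is expected, back toward compound 1. Compound 3 is therefore estimated at 2000 nM, with a range from 800 nM to 5000 nM.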

Compound 3, half-maximal effective concentration: 900 nM
Compound 3: middle estimate off by 2.2-fold (0.35 log units), on the high side, within the range that was stated.
By their numbers in this assay, from the lowest: compounds 3 and 1 (each within the scatter of the next); then compound 2.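

In this assay the exchange of 2-methoxyphenyl for 4-fluorophenyl gives a 3.6-fold lower number from compound 2 to compound 3 (0.55 log units; beyond the scatter), so even with a six-membered aromatic ring of carbon only on both sides of the step, what that ring carries, or where it carries it, moves the number. Thiophen-2-yl and 4-fluorophenyl cannot be told apart here, since a 1.7-fold lower number from compound 1 to compound 3 (0.22 log units; within the scatter) is a step within the scatter, which leaves 2-methoxyphenyl as the one group of the three that stands apart. Nothing available explains why the number moves with these groups.

The step changes both the atoms on the ring and their place, and only a pair such as 4-methoxyphenyl and 2-fluorophenyl could separate those two changes. Going by these compounds, whether plain phenyl or a ring bearing a carboxylic acid would fall in with compound 1 and compound 3 also remains open.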